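The source may hold more compounds than are shown below. What is called first, only, known or untested is meant among the compounds shown, and "the series" means these compounds.

Measured so far:
compound 1, `Cc1nc(CN2CCN(c3cccc4[nH]c(-c5ccc(C(C)(C)C)cc5)nc34)CC2)c[nH]1`: 28 nM
compound 2, `Cc1nc(CN2CCN(c3cccc4[nH]c(-c5ccc(C(C)(C)C)cc5)nc34)CC2)cn1C`: 34 nM

Both were tested in an assay on isolated protein for displacement of a labelled ligand from Gonadotropin-releasing hormone receptor (Rattus norvegicus); on this read-out lower numbers stand for stronger inhibition and higher numbers for weaker inhibition. Within the data shown here, compound 2 sits at the top of these two numbers, but the only recorded step, a 1.2-fold higher number from compound 1 to compound 2 (0.08 log units; within the scatter), lies within the scatter, so the two compounds cannot be told apart on this read-out. Compound 3, `CCCn1c(CC)nc(C)c1CN1CCN(c2cccc3[nH]c(-c4ccc(C(C)(C)C)cc4)nc23)CC1`, has not yet been measured in this assay. It differs from compound 2 by 2-ethyl-4-methyl-1-propyl-1H-imidazol-5-yl in place of 1,2-dimethyl-1H-imidazol-4-yl on a saturated chain carbon bound to an amine nitrogen in a ring. Among the measured compounds shown here, the one measured step bears on it only loosely: putting a methyl on the ring nitrogen changed nothing beyond the scatter. For the measured compounds named here, compound 3 carries longer chains and, as the names show, attaches through a different ring position, and no measured step covers that. The expectation is therefore a step of a 1.2-fold higher number from compound 2 to compound 3 (0.07 log units; within the scatter), within the scatter. Compound 3 is estimated at 40 nM, with a range from 12 nM to 130 nM.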

Compound 3, half-maximal inhibitory concentration: 120 nM
Estimate against measurement, compound 3: 3.0-fold (0.48 log units) below; low and high end bracket the measured number.
By their numbers in this assay, from the lowest: compounds 1 and 2 (each within the scatter of the next); then compound 3.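

In this assay, this position on a saturated chain carbon bound to an amine nitrogen in a ring turns out to respond to the group it carries: 2-ethyl-4-methyl-1-propyl-1H-imidazol-5-yl gives a 3.5-fold higher number from compound 2 to compound 3 (0.55 log units; beyond the scatter), and measured against the 2-methyl-1H-imidazol-4-yl group it gives a 4.3-fold higher number from compound 1 to compound 3 (0.63 log units; beyond the scatter). The earlier pair showed only that a methyl on the ring nitrogen made no readable difference, whereas this larger change, 11 heavy atoms in place of 7, weakens inhibition modestly without removing it. No measurement shown here explains this loss.

From the compounds shown here alone, the change alters the attachment point and adds the ethyl and propyl chains all at once, so the share of each stays unknown. Going by these compounds, it is also open how a different ring, such as a plain phenyl or a pyridine, would fare at this position.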